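The compounds below may be only part of what the source reports. "The series", "measured", "known", "first", "only" and "open" are said of these compounds alone.

Compound 1 `O=C(CSc1nnc(-c2ccncc2)n1-c1ccccc1)N/N=C/c1ccc(O)cc1` — > 50000 nM
Compound 2 `O=C(CSc1nnc(-c2ccncc2)n1-c1ccccc1)N/N=C/c1ccc(Br)cc1` — 4500 nM

In a functional assay on HCT-116 cells (Homo sapiens) for inhibition, read by MTT assay, with a stated time of 48 h (a lower number here means a stronger inhibitor, a higher number a weaker inhibitor), compound 1 reaches only the limit of the assay, > 50000 nM. For the measured compounds named here, compound 2 gives 4500 nM in this assay and is the only compound here with an actual number. The other value shown, that of compound 1, is a limit (the limit of > 50000 nM in this assay, at which 1 of the 2 values shown sits). Going by the values given here, the single measured step, an at least 11-fold lower number from compound 1 to compound 2 (1.04 log units; beyond the scatter), is the only guide for what follows. Compound 3 `O=C(CSc1nnc(-c2ccncc2)n1-c1ccccc1)N/N=C/c1ccccc1F` differs from compound 2 by 2-fluorophenyl in place of 4-bromophenyl on a carbon with a double bond to nitrogen. Among the compounds with values here, a halogen remains on the ring, so this is not the reverse of the measured step, but the substituent changes both in kind and in its named position, and no measured pair covers such a change. The estimate for compound 3 is 9000 nM, within 2500 nM to 40000 nM. That estimate means a step of a 2.0-fold higher number from compound 2 to compound 3 (0.30 log units; within the scatter), expected to stay close to the scatter, with a real chance that only a limit is returned.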

Compound 3, half-maximal inhibitory concentration: 18000 nM
Estimate against measurement, compound 3: 2.0-fold (0.30 log units) below, within the range that was stated.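

In this assay, the exchange on a carbon with a double bond to nitrogen gives a 4.0-fold higher number from compound 2 to compound 3 (0.60 log units; beyond the scatter), so this place separates 4-bromophenyl from 2-fluorophenyl, although both are halogen-bearing rings and match in what is counted for them. Set against 4-hydroxyphenyl, 2-fluorophenyl gives an at least 2.7-fold lower number from compound 1 to compound 3 (0.44 log units; beyond the scatter), so both halogen-bearing rings shown now go with a lower number than the hydroxy-bearing ring, with no compound shown going against this. Compound 1 remains a limit and not a number: the limit of > 50000 nM in this assay, at which 1 of the 3 values shown sits.

The step from compound 2 to compound 3 changes the halogen and its named position together, so the compounds shown cannot separate the two changes. They also leave open how a ring carrying an amine or a methoxy group would compare at this place.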